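Swapping methyl for chloro on a 2-aminophenyl amide

The compounds below may be only part of what the source reports. "The series", "measured", "known", "first", "only" and "open" are said of these compounds alone.

Measured in a functional assay on U-937 cells (Homo sapiens) for antiproliferative activity, read by MTT assay, with a stated time of 72 h; a higher number here means a weaker inhibitor, a lower number a stronger inhibitor:
Compound 1 `Cc1ccc(-c2noc(CCCCCCC(=O)NO)n2)cc1` gives 1360 nM
Compound 2 `O=C(CCCCCCc1nc(-c2cccc([N+](=O)[O-])c2)no1)NO` gives 1160 nM
Compound 3 `Cc1ccc(-c2noc(CCCCCCC(=O)Nc3ccccc3N)n2)cc1` gives 460 nM

Compound 3 has the lowest of these three numbers, which makes it the natural starting point. Compound 4 `Nc1ccccc1NC(=O)CCCCCCc1nc(-c2ccc(Cl)cc2)no1` differs from compound 3 in one place: chloro in place of methyl on an aromatic carbon. Put simply, 4-methylphenyl becomes 4-chlorophenyl.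

Among the measured compounds shown here, only one measured step is available, a 3.0-fold lower number from compound 1 to compound 3 (0.47 log units; beyond the scatter). This modest step put 2-aminophenyl in place of hydroxy on an amide-type nitrogen, which is not the place that changes now, so it offers little guidance. For the measured compounds named here, no measured step swaps a single group on the aromatic ring. Compound 1 at 1360 nM and compound 2 at 1160 nM carry different groups there, yet their numbers lie within the usual scatter of each other.

No step beyond the scatter is therefore expected in this assay. The estimated step is a 1.1-fold lower number from compound 3 to compound 4 (0.03 log units; within the scatter). For compound 4 the expected value is 430 nM, with an estimated range of 200 nM to 920 nM.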

Compound 4, half-maximal inhibitory concentration: 4360 nM
Compound 4: middle estimate off by 10-fold (1.01 log units), on the low side; measured number outside the range, above it.
By their numbers in this assay, from the lowest: compound 3; then compounds 2 and 1 (each within the scatter of the next); then compound 4.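

In this assay, among the compounds shown here, chloro in place of methyl gives a 9.5-fold higher number from compound 3 to compound 4 (0.98 log units; beyond the scatter), the first measured single swap at this place on the aromatic ring. The change is large for so small an edit: methyl and chloro match in every count computed for them, including heavy atoms, rings, hydrogen-bond donors and acceptors, and net charge, so those counts do not separate compound 3 from compound 4. Nothing shown gives a reason for this step.

As far as these compounds go, whether the same swap has a similar effect when the hydroxy amide of compound 1 replaces the 2-aminophenyl amide stays open. Also open, from the compounds shown here alone, is where other groups at this place, such as fluoro, methoxy or an amine, would fall relative to methyl and chloro.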